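Swapping the quinoline of compound 3 for a lactam bicycle

The source may hold more compounds than are shown below. What is called first, only, known or untested is meant among the compounds shown, and "the series" means these compounds.

Compound 1 `Cn1c(=O)c(S(=O)(=O)c2ccc(F)cc2F)cc2cnc(Nc3ccc4cc[nH]c4c3)nc21` gives 5000 nM in a functional assay on DU-145 cells (Homo sapiens) for inhibition, read by trypan blue exclusion, with a stated time of 72 h; a lower number here means a stronger inhibitor, a higher number a weaker inhibitor.
Compound 2 `Cn1c(=O)c(S(=O)(=O)c2ccc(Cl)cc2)cc2cnc(Nc3ccc4[nH]ccc4c3)nc21` gives 250 nM in this assay.
Compound 3 `Cc1ccc(S(=O)(=O)c2cc3cnc(Nc4cccc5cccnc45)nc3n(C)c2=O)cc1` gives 10000 nM in this assay.

Among these three, compound 3 carries the highest number. Its gap to compound 1 lies within the scatter, so the two cannot be ordered; its gap to compound 2 lies beyond the scatter, so compound 2 is the stronger inhibitor of that pair. The unmeasured compound 4 `Cc1ccc(S(=O)(=O)c2cc3cnc(Nc4cnc5c(c4)CC(=O)N5)nc3n(C)c2=O)cc1` keeps the shared core and the sulfonyl of compound 3 and changes only the group on the nitrogen on an aromatic ring: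

a group of 10 heavy atoms (7 carbon, 2 nitrogen, 1 oxygen; one five-membered non-aromatic ring with 1 hetero atom, one six-membered aromatic ring with 1 hetero atom) in place of a group of 10 heavy atoms (9 carbon, 1 nitrogen; one six-membered aromatic ring of carbon only, one six-membered aromatic ring with 1 hetero atom), on a nitrogen on an aromatic ring

Within the data shown here, no measured pair in this set differs in one place alone, so the size of this step cannot be read from a neighbour. Among the measured compounds shown here, compound 2, the only compound here that also brings a hydrogen-bond donor on that side, shows the lowest number; compound 1, also with a donor, does not. Compound 4 is therefore expected to land at 3000 nM, within a range from 800 nM to 12000 nM. The expected step is a 3.3-fold lower number from compound 3 to compound 4 (0.52 log units; beyond the scatter), a modest move toward a stronger inhibitor that may not exceed the scatter.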

Compound 4, half-maximal inhibitory concentration: 15000 nM
Compound 4: middle estimate off by 5.0-fold (0.70 log units), on the low side; the whole stated range lies below it.
By their numbers in this assay, from the lowest: compound 2; then compounds 1, 3 and 4 (each within the scatter of the next, the first and the last beyond it).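

In this assay, putting the group with a five-membered non-aromatic ring and a six-membered aromatic ring in place of quinolin-8-yl, on a nitrogen on an aromatic ring, gives a 1.5-fold higher number from compound 3 to compound 4 (0.18 log units; within the scatter) and so leaves the two compounds unordered. Among these compounds, this is the first step at this position that can be read on its own: the group that enters brings a hydrogen-bond donor that quinolin-8-yl lacks, and in this pair the number does not move beyond the scatter. No data given here offer an explanation for this result.

Compound 2 differs from compound 3 in more than one place, so the source of its lower number cannot be assigned to either change. On these data alone, how a phenyl ring carrying a piperazine would fare on this nitrogen remains open.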